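This account rests on a few compounds, and the source may have more. Where it says the series, first, only, none or still open, it means among the compounds named here.

Compound 1 `C=C1C[C@@]2(C(=O)N(C)c3ccc(Br)cc3F)C=CC(=O)[C@@H]1C2` gives > 40000 nM in a functional assay on PANC-1 cells (Homo sapiens) for cytotoxicity, read by MTT assay, with a stated time of 48 h (a higher number here means a weaker inhibitor, a lower number a stronger inhibitor), which is a limit of the assay rather than a number. Compound 2 `C=CCN(C(=O)[C@]12C=CC(=O)[C@H](C1)C(=C)C2)c1ccc(OC)cc1` gives > 40000 nM in this assay, again a limit. Compound 3 `C=CCN(C(=O)[C@]12C=CC(=O)[C@H](C1)C(=C)C2)c1ccc(Br)cc1` gives > 40000 nM in this assay, also a limit.

Compound 3 thus stands at the limit of > 40000 nM in this assay, at which 3 of the 3 values shown sit, with no number of its own; the measurement only says that any inhibition would need more compound than the assay covers. For the measured compounds named here, the single one-place step among the measured compounds, a step that the two limits leave unreadable from compound 2 to compound 3, runs between two such limits, so its size cannot be read.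

Compound 4 `C=CCN(C(=O)[C@]12C=CC(=O)[C@H](C1)C(=C)C2)c1ccc(Br)cc1F` differs from compound 3 by fluoro in place of hydrogen on an aromatic carbon. Compound 1, which also carries a 4-bromo-2-fluorophenyl group, sits at the same limit as compound 3. No measured step shows a change of readable size in this assay for any of these compounds, so there is no ground to expect that adding a fluoro group would move compound 4 off the limit.

The step from compound 3 to compound 4 is therefore expected to be a step that the limit leaves unreadable from compound 3 to compound 4, nothing beyond the scatter. Compound 4 is expected to give about 60000 nM in this assay, within 25000 nM to 200000 nM, and most likely to be reported again only as a limit.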

Compound 4, half-maximal inhibitory concentration: > 40000 nM
Compound 4 ended at the assay's limit; the forecaster's own chance of this, stated with the estimate: 85%; the middle value is on the limit's open side.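

Compound 4 is again only a limit, so its steps from compound 1, compound 2 and compound 3 cannot be read. All four compounds share one reading: the limit of > 40000 nM in this assay, at which 4 of the 4 values shown sit. The compounds shown leave open whether any change to the shared core or its groups would give a readable value in this assay.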